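A few compounds are considered here, and "the series" means these few. Any claim that something is new, unique, unknown or untested is made for them only; others in the source may bear on it.

Compound 2 `COc1ccc2nccc(C3CN(C4CCN(C)CC4)C(=O)O3)c2c1` stands at the weak end of what has been measured. In an in vitro functional assay on RBL cells for antagonist activity at C-C chemokine receptor type 8 (Homo sapiens), read by FLIPR and calcium flux (on this read-out higher numbers stand for weaker inhibition and lower numbers for stronger inhibition), compound 2 reaches only a limit, < 50200 nM. Compound 1 `COc1ccc2nccc(C3CN(C4CCN(Cc5cc6ccccc6s5)CC4)C(=O)O3)c2c1` in this assay gives 794 nM. Among the measured compounds shown here, the one measured step, a step that the limit leaves unreadable from compound 1 to compound 2, cannot be sized because of the limit of < 50200 nM in this assay, at which 1 of the 2 values shown sits. Compound 3 `COc1ccc2nccc(C3CN(C4CCN(Cc5ccccc5)CC4)C(=O)O3)c2c1` differs from compound 2 by phenyl in place of hydrogen on a saturated chain carbon bound to an amine nitrogen in a ring, restoring part of what compound 1 carries. The step from compound 2 to compound 3 is therefore expected to lower the value, a step that the limit leaves unreadable from compound 2 to compound 3, though no readable step sets its size. Compound 3 is estimated at 3000 nM, between 700 nM and 20000 nM.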

Compound 3, half-maximal inhibitory concentration: 12600 nM
Estimate against measurement, compound 3: 4.2-fold (0.62 log units) below; the measured number falls inside the stated range.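

In this assay, phenyl in place of 1-benzothiophen-2-yl gives a 16-fold higher number from compound 1 to compound 3 (1.20 log units; beyond the scatter) on this saturated chain carbon bound to an amine nitrogen in a ring. So the identity of the aromatic group here matters, and phenyl does not match 1-benzothiophen-2-yl. The steps that involve compound 2 cannot be read, because its value is only a limit: (the limit of < 50200 nM in this assay, at which 1 of the 3 values shown sits).

Open, going by these compounds, is how 1-benzofuran-2-yl or naphthalen-2-yl would fare at this place. Either would show whether the larger ring system or its sulfur atom goes with the lower number.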